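Adding a Chloro Substituent to a Thiazole Amide Series

The source may report more compounds than this note shows. Statements on the series, on what has been measured and on what is new or still open speak of the compounds shown alone.

Going by the values given here, compound 1 `Cc1ccc(-c2csc(NC(=O)COc3ccccc3)n2)cc1` is one of three compounds measured in a functional assay on MDA-MB-468 cells (Homo sapiens) for cytotoxicity, read by MTT assay, with a stated time of 48 h (on this read-out lower numbers stand for stronger inhibition and higher numbers for weaker inhibition), where compound 1 gives 54900 nM. That is the second highest of the three numbers, yet all three sit close together. Compound 2 `Cc1ccc(-c2csc(NC(=O)COc3ccccc3C(C)C)n2)cc1` gives 55500 nM, and compound 3 `O=C(COc1ccccc1)Nc1nc(-c2ccc(Br)cc2)cs1` gives 37200 nM. Among the compounds with values here, the step of a 1.0-fold higher number from compound 1 to compound 2 (0.00 log units; within the scatter) and the step of a 1.5-fold lower number from compound 1 to compound 3 (0.17 log units; within the scatter) both stay within the scatter, so nothing so far separates these compounds in this assay.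

Compound 4 `Cc1ccc(-c2csc(NC(=O)COc3ccc(Cl)cc3)n2)cc1` has not yet been measured. It differs from compound 1 by chloro in place of hydrogen on an aromatic carbon, which turns the phenoxy of compound 1 into 4-chlorophenoxy. Within the data shown here, of the measured steps, the one from compound 1 to compound 2 is the closest relative, since it too replaces a ring hydrogen of compound 1 with a new substituent, and that step was flat; the step to compound 3 exchanges one aromatic substituent for another and was equally flat. On this basis the expected step of a 1.1-fold lower number from compound 1 to compound 4 (0.04 log units; within the scatter) is none beyond the scatter. Compound 4 is therefore estimated at 50000 nM, with a range from 25000 nM to 100000 nM.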

Compound 4, half-maximal inhibitory concentration: 44200 nM
Compound 4: the middle estimate sits 1.1-fold (0.05 log units) above what was measured; the range from low to high includes it.
By their numbers in this assay, from the lowest: compounds 3, 4, 1 and 2 (each within the scatter of the next).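

Putting a chloro on the phenoxy ring of compound 1, to give the 4-chlorophenoxy of compound 4, produces a small shift in this assay (a 1.2-fold lower number from compound 1 to compound 4 (0.09 log units; within the scatter)), so a halogen at this position, para to a large group, is tolerated without a change that can be told from assay noise. Compound 2 carries an isopropyl on the same ring and also stays within the scatter (a 1.0-fold higher number from compound 1 to compound 2 (0.00 log units; within the scatter)), which means that two quite different substituents on this ring, a single chlorine atom and a branched carbon group, have now left the number of compound 1 effectively in place, with no compound shown going against this. None of the information available explains why this ring position responds so little.

The compounds shown leave open whether a group of another kind here, such as an amine or a carboxylic acid, would move the number beyond the scatter. They also leave open what a longer chain between the amide carbonyl and the phenoxy oxygen would do, as every change so far has been made on an aromatic ring.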